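Morpholine sulfonamide on a nitroimidazole core: expected cytotoxicity

The source may report more compounds than this note shows. Statements on the series, on what has been measured and on what is new or still open speak of the compounds shown alone.

Going by the values given here, compound 2 `Cc1ncc([N+](=O)[O-])n1CCS(=O)(=O)NCCCN(C)C` holds the highest of the two numbers measured so far: in a functional assay on HCT-116 cells (Homo sapiens) for cytotoxicity, read by sulforhodamine B assay, with stated times of 4 h and 5 days (a lower number here means a stronger inhibitor, a higher number a weaker inhibitor), compound 2 gives 1200000 nM, while compound 1 `Cc1ncc([N+](=O)[O-])n1CCS(=O)(=O)NCCO` gives 400000 nM. Among the compounds with values here, the only measured step bearing on the sulfonamide substituent is a 3.0-fold higher number from compound 1 to compound 2 (0.48 log units; beyond the scatter). Compound 3 `Cc1ncc([N+](=O)[O-])n1CCS(=O)(=O)N1CCOCC1` carries morpholin-4-yl in place of (3-(dimethylamino)propyl)amino on a sulfonyl sulfur. Since that earlier change moved the number only modestly, compound 3 is expected to land near compound 1 or between the two, a step of a 2.0-fold lower number from compound 2 to compound 3 (0.30 log units; within the scatter). Compound 3 is therefore estimated at 600000 nM, within 250000 nM to 1500000 nM.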

Compound 3, half-maximal inhibitory concentration: 38000 nM
Beside the measured number, compound 3's estimate is 16-fold (1.20 log units) above it; the measured number lies below the stated range.
By their numbers in this assay, from the lowest: compound 3; then compound 1; then compound 2.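

At the sulfonyl sulfur, morpholin-4-yl gives a 32-fold lower number from compound 2 to compound 3 (1.50 log units; beyond the scatter) and an 11-fold lower number from compound 1 to compound 3 (1.02 log units; beyond the scatter) in this assay. Both steps are large, whereas the exchange of one open chain for another earlier gave only a modest 3.0-fold higher number from compound 1 to compound 2 (0.48 log units; beyond the scatter), so this position can shift the number much further than that exchange showed. No measured evidence accounts for the change. In compound 3 the ring, its oxygen and the loss of the hydrogen-bond donor all arrive together. A piperidin-1-yl or 4-methylpiperazin-1-yl group would begin to separate these features.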